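This account rests on a few compounds, and the source may have more. Where it says the series, first, only, none or still open, it means among the compounds named here.

Measured so far:
compound 1 `CC1=C(C(=O)SC(C)C)C(c2ccoc2)NC(=O)N1` — 637 nM
compound 2 `CCC(C)OC(=O)C1=C(C)NC(=O)NC1c1ccco1` — 84.3 nM

In an assay on membranes from HEK293 cells for displacement of a labelled ligand from adenosine receptor A2b (Homo sapiens), read by scintillation counting, with a stated time of 30 min (on this read-out lower numbers stand for stronger inhibition and higher numbers for weaker inhibition), compound 2 gives 84.3 nM, the lowest of the two numbers; compound 1 gives 637 nM, a higher number that lies beyond the scatter, and the two structures differ in more than one place, so no single change can be read from that pair. Compound 3 `CCC(C)OC(=O)C1=C(C)NC(=O)NC1c1ccoc1` differs from compound 2 in one place: furan-3-yl in place of furan-2-yl on a saturated ring carbon. Going by the values given here, no measured pair shows this change on its own. A modest rise in this assay is expected, shown as a 2.4-fold higher number from compound 2 to compound 3 (0.38 log units; beyond the scatter), though a change within the scatter would not surprise. Compound 3 is expected to give about 200 nM, within 70 nM to 600 nM.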

Compound 3, inhibition constant: 201 nM
The estimate for compound 3 lay 1.0-fold (0.00 log units) below the measured number, within the range that was stated.
By their numbers in this assay, from the lowest: compound 2; then compound 3; then compound 1.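

In this assay furan-3-yl in place of furan-2-yl on a saturated ring carbon gives a 2.4-fold higher number from compound 2 to compound 3 (0.38 log units; beyond the scatter) and so shows that the point of attachment of the furan matters here, even with the same atoms. Going by these compounds alone, compound 3 also links the earlier compounds: a 3.2-fold lower number from compound 1 to compound 3 (0.50 log units; beyond the scatter) comes with sec-butoxy in place of isopropylsulfanyl on a carbonyl carbon. No measurement shown explains either step. Still open, going by these compounds, is how phenyl or thiophene on the saturated ring carbon would compare, and how an amine or a longer chain would compare in place of sec-butoxy.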